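The source may report more compounds than this note shows. Statements on the series, on what has been measured and on what is new or still open speak of the compounds shown alone.

Compound 1 `CCOC(=O)[C@@]1(C(=O)Nc2ccccc2)C[C@@H]1c1cc(OC)c(OC)c(OC)c1`: > 100000 nM
Compound 2 `CCOC(=O)[C@]1(C(=O)Nc2ccccc2)C[C@H]1c1cc(OC)c(OC)c(OC)c1`: > 100000 nM

Both results come from a functional assay on SW480 cells (Homo sapiens) for cytotoxicity, read by MTT assay, with a stated time of 48 h (on this read-out lower numbers stand for stronger inhibition and higher numbers for weaker inhibition), and each is a limit of the assay, not a number. Compound 2 gives > 100000 nM, which is a limit. It therefore has no exact place on the scale and shares its position with the other measured compound: the limit of > 100000 nM in this assay, at which 2 of the 2 values shown sit.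

Compound 3 `CCOC(=O)[C@]1(C(=O)Nc2ccccc2)C[C@@H]1c1cc(OC)c(OC)c(OC)c1` is closely related to compound 2: the two compounds have the same atoms and bonds and differ only in configuration as drawn: 1 of 2 stereo elements differ; a stereocentre at a saturated ring carbon is drawn S in compound 2 and R in compound 3. Among the compounds with values here, the one measured step that bears on this change is a step that the two limits leave unreadable from compound 1 to compound 2. It concerns (the fact that compounds 1 and 2 differ only in the configuration as drawn), but it provides no size to carry over. Since both mirror images sit at the limit, no clear gain is expected in this assay, although these data cannot rule one out. The expected step is a number no higher from compound 2 to compound 3 (the limit leaves the size open). For compound 3, the estimate is 100000 nM, with an expected range from 30000 nM to 200000 nM.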

Compound 3, half-maximal inhibitory concentration: 31700 nM
The estimate for compound 3 lay 3.2-fold (0.50 log units) above the measured number; low and high end bracket the measured number.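

In this assay, the drawn configuration at the saturated ring carbons can matter: changing one stereocentre gives an at least 3.1-fold lower number from compound 2 to compound 3 (0.49 log units; beyond the scatter), and changing the other gives an at least 3.1-fold lower number from compound 1 to compound 3 (0.49 log units; beyond the scatter). The earlier pair could not show this, as the step between compound 1 and compound 2 cannot be read when both values are limits. No atom or bond changes along the step to compound 3, so the shift from compound 2 can be traced to configuration alone: the fact that compounds 2 and 3 differ only in the configuration as drawn

Going by these compounds, it remains open how the mirror image of compound 3 would compare, which would show whether the effect belongs to one stereocentre or to the relation between the two. On these data alone, it is also open whether a carboxylic acid or an amine on the shared core would lower the number further.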